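The source may hold more compounds than are shown below. What is called first, only, known or untested is meant among the compounds shown, and "the series" means these compounds.

Measured series:
Compound 1 `COc1cc2c(Oc3ccc(NC(=O)c4cc(-c5ccccc5)ccn4)cc3F)ccnc2cc1OCCCN1CCCC1` — in a functional assay on NCI-H460 cells (Homo sapiens) for cytotoxicity, read by MTT assay, with a stated time of 72 h (on this read-out lower numbers stand for stronger inhibition and higher numbers for weaker inhibition), compound 1 gives 130 nM.
Compound 2 `COc1cc2c(Oc3ccc(NC(=O)c4cc(-c5ccc(C)cc5)ccn4)cc3F)ccnc2cc1OCCCN1CCCC1` — in this assay compound 2 gives 160 nM.
Compound 3 `COc1cc2c(Oc3ccc(NC(=O)c4cc(-c5ccc(C(F)(F)F)cc5)ccn4)cc3F)ccnc2cc1OCCCN1CCCC1` — in this assay compound 3 gives 250 nM.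

Compound 3 carries the highest number of the three, yet its gaps to the others stay within the scatter: a 1.9-fold higher number from compound 1 to compound 3 (0.28 log units; within the scatter) and a 1.6-fold higher number from compound 2 to compound 3 (0.19 log units; within the scatter). Compound 4 `COc1ccc(-c2ccnc(C(=O)Nc3ccc(Oc4ccnc5cc(OCCCN6CCCC6)c(OC)cc45)c(F)c3)c2)cc1` is not yet measured; the change is methoxy in place of trifluoromethyl on an aromatic carbon. Among the compounds with values here, the steps that bear on it are the earlier swaps at the same carbon, a 1.2-fold higher number from compound 1 to compound 2 (0.09 log units; within the scatter) and a 1.9-fold higher number from compound 1 to compound 3 (0.28 log units; within the scatter), none of them beyond the scatter. No shift beyond the scatter is therefore expected in this assay for compound 4, the estimated step being a 1.4-fold lower number from compound 3 to compound 4 (0.14 log units; within the scatter). Compound 4 is estimated at 180 nM, with a range from 80 nM to 400 nM.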

Compound 4, half-maximal inhibitory concentration: 200 nM
Estimate against measurement, compound 4: 1.1-fold (0.05 log units) below; the measured number falls inside the stated range.
By their numbers in this assay, from the lowest: compounds 1, 2, 4 and 3 (each within the scatter of the next).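

In this assay, methoxy brings the first oxygen-linked group and the first hydrogen-bond acceptor to this carbon of the 4-substituted phenyl, and the number stays within the scatter of all three earlier compounds (a 1.3-fold lower number from compound 3 to compound 4 (0.10 log units; within the scatter); a 1.3-fold higher number from compound 2 to compound 4 (0.10 log units; within the scatter); a 1.5-fold higher number from compound 1 to compound 4 (0.19 log units; within the scatter)). Hydrogen, methyl, trifluoromethyl and methoxy at this carbon therefore cannot be ordered in this series. No measurement offers an explanation for this flat result.

Going by these compounds, whether an amine, a carboxylic acid or a longer alkoxy chain at this carbon would produce a step beyond the scatter remains open.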